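Pyridin-2-yl for thiophen-3-yl: working notes on compound 4

This account rests on a few compounds, and the source may have more. Where it says the series, first, only, none or still open, it means among the compounds named here.

Values so far in a toxicity assay on J774.A1 cells (Mus musculus) for cytotoxicity, read by SYBR Green assay, with a stated time of 1 h (a higher number here means that more compound is needed for the effect, a lower number that less compound is needed), are as follows.
- compound 1 (`CN(C)c1ccc2cc(-c3ccccc3F)c(N)nc2c1`) gives 1600 nM
- compound 2 (`CN(C)c1ccc2cc(-c3ccccc3Cl)c(N)nc2c1`) gives 2400 nM
- compound 3 (`CN(C)c1ccc2cc(-c3ccsc3)c(N)nc2c1`) gives "not determined" (no result reported)

Compound 3 therefore has no number in this assay and offers no starting value for the next step. The change to compound 4 (`CN(C)c1ccc2cc(-c3ccccn3)c(N)nc2c1`) puts pyridin-2-yl in place of thiophen-3-yl on an aromatic carbon, ortho to an amino group pyridin-2-yl in place of thiophen-3-yl on an aromatic carbon and the shared core stays as it is.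

Among the measured compounds shown here, only one measured step is available. It runs a 1.5-fold higher number from compound 1 to compound 2 (0.18 log units; within the scatter) and stays within the scatter. It is a chloro in place of fluoro exchange, not the exchange made here, so it bears on the new step only indirectly. It shows a single case in which one substituent exchange left the number within the scatter.

With no number for compound 3, no size or direction can be assigned to the step itself. The expectation rests instead on the level set by compound 1 at 1600 nM and compound 2 at 2400 nM in this assay for the same core.

Compound 4 is expected at 2500 nM with an estimated range from 800 nM to 8000 nM in this series.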

Compound 4, half-maximal effective concentration: 2200 nM
Compound 4: the middle estimate sits 1.1-fold (0.06 log units) above what was measured, within the range that was stated.
By their numbers in this assay, from the lowest: compounds 1, 4 and 2 (each within the scatter of the next).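

In this assay, the compounds with a number at this position, an aromatic carbon ortho to an amino group, now include one whose ring carries a hetero atom, and pyridin-2-yl in place of the halogen-bearing phenyl rings gives a 1.1-fold lower number from compound 2 to compound 4 (0.04 log units; within the scatter) and a 1.4-fold higher number from compound 1 to compound 4 (0.14 log units; within the scatter). Compounds 1, 2 and 4 therefore stand at one level in this assay, so the earlier result for a chloro and fluoro exchange now extends to an exchange of the whole ring, though only for these three compounds. Compound 3 has no number and the step from it to compound 4 cannot be read, and no supporting measurement bears on why the values stay together.

Still open, from the compounds shown here alone, is whether a ring-free group at this position, such as an aminomethyl group, a carboxylic acid or a longer alkyl chain, would give a step beyond the scatter. Also open, going by these compounds, is where thiophen-3-yl stands against pyridin-2-yl, and whether the level shared by compounds 1, 2 and 4 would hold for a morpholine ring in the same place.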